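Swapping 4-methoxyphenyl for 3-hydroxyphenyl on the shared core

The source may report more compounds than this note shows. Statements on the series, on what has been measured and on what is new or still open speak of the compounds shown alone.

Compound 1 `COc1ccc(Nc2nc(-c3cccc(F)c3)nc3ccc(F)cc23)cc1` gives 46800 nM in a functional assay on COLO 205 cells (Homo sapiens) for cytotoxicity, read by MTT assay, with a stated time of 48 h; a higher number here means a weaker inhibitor, a lower number a stronger inhibitor. Compound 2 `Fc1cccc(-c2nc(Nc3ccc(Br)cc3)c3cc(F)ccc3n2)c1` reaches only the limit > 50000 nM. Compound 3 `Fc1cccc(-c2nc(Nc3cccc(Br)c3)c3cc(F)ccc3n2)c1` likewise reaches only the limit > 50000 nM.

Among the measured compounds shown here, compound 1 is thus the one compound with a number; the other two sit at the limit of > 50000 nM in this assay, at which 2 of the 3 values shown sit. Compound 4 `Oc1cccc(Nc2nc(-c3cccc(F)c3)nc3ccc(F)cc23)c1` differs from compound 1 in this way: 3-hydroxyphenyl in place of 4-methoxyphenyl on a nitrogen on an aromatic ring.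

Two measured steps change the same group on the same nitrogen. From compound 1 to compound 2 the step is an at least 1.0-fold higher number from compound 1 to compound 2 (0.02 log units; that floor lies within the scatter), and from compound 1 to compound 3 it is an at least 1.0-fold higher number from compound 1 to compound 3 (0.02 log units; that floor lies within the scatter). Both set only a floor that lies within the scatter, and neither involved a hydroxyl, so they say little about the present change. The expectation for compound 4 is therefore a step within the scatter: the estimated step is a 1.0-fold lower number from compound 1 to compound 4 (0.02 log units; within the scatter). Compound 4 is expected to give about 45000 nM in this assay, with a range from 15000 nM to 140000 nM.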

Compound 4, half-maximal inhibitory concentration: > 50000 nM
Compound 4: only a limit was reported; the forecaster's own chance of this, stated with the estimate: 45%; at least 1.1-fold (0.04 log units) between middle value and limit.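

In this assay compound 4 gives > 50000 nM, which is a limit and not a number. Among the compounds shown here, putting 3-hydroxyphenyl in place of 4-methoxyphenyl on the nitrogen gives an at least 1.0-fold higher number from compound 1 to compound 4 (0.02 log units; that floor lies within the scatter), so a hydroxyl on this phenyl ring, the first group here with a hydrogen-bond donor, brings no readable gain, while the steps from compound 2 and compound 3 to compound 4 cannot be read. Compound 4 thus joins the two bromo compounds, and compound 1 remains the only one of the four with a number: the limit of > 50000 nM in this assay, at which 3 of the 4 values shown sit.

Going by these compounds, how far compound 2, compound 3 and compound 4 lie beyond that limit stays open, so these three cannot be ranked. Also open, on these data alone, is whether an amine or a carboxylic acid on this phenyl ring would give a measurable value.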